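Swapping an Ethylamide for a Branched Ester

This account rests on a few compounds, and the source may have more. Where it says the series, first, only, none or still open, it means among the compounds named here.

Compound 1 `CC1=C(C(=O)OCc2ccccc2)C(c2ccco2)NC(=O)N1` and compound 2 `CCNC(=O)C1=C(C)NC(=O)NC1c1ccco1` share one core and differ only in the group attached to the carbonyl carbon. In an assay on membranes from HeLa cells for displacement of a labelled ligand from adenosine receptor A3 (Homo sapiens), read by scintillation counting, with a stated time of 180 min, tested at 1 uM (a higher number here means more inhibition at the concentration tested (going by the name of the read-out), a lower number less inhibition), compound 1 gives 3%, and in this assay compound 2 gives 3%. The two values sit level within the usual scatter, so compound 2 stands no differently from compound 1. Compound 3 `CCC(CC)OC(=O)C1=C(C)NC(=O)NC1c1ccco1` awaits measurement; it differs from compound 2 by (pentan-3-yl)oxy in place of ethylamino on a carbonyl carbon. Both measured values show almost no displacement, so the step of a number 1 percentage points higher from compound 2 to compound 3 (within the scatter) is expected to stay within the scatter. Compound 3 is estimated at 4%, with a range from -5% to 15%.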

Compound 3, a percentage reported as inhibition, at one concentration (the size of the read-out at that concentration, not a potency): 1%
Estimate against measurement, compound 3: 3 percentage points above; the range from low to high includes it.
By their numbers in this assay, from the lowest: compounds 3, 1 and 2 (each within the scatter of the next).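

In this assay, (pentan-3-yl)oxy in place of ethylamino gives a number 2 percentage points lower from compound 2 to compound 3 (within the scatter), and pentan-3-yl in place of benzyl on an oxygen next to a carbonyl group gives a number 2 percentage points lower from compound 1 to compound 3 (within the scatter). Exchanging the hydrogen-bond donor of ethylamino for the larger (pentan-3-yl)oxy, or benzyl for pentan-3-yl, therefore leaves the read-out within the scatter. Nothing available explains this flat result. As far as these compounds go, whether a carboxylic acid on this carbonyl carbon, or a longer chain on the oxygen, would give clear displacement remains open.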